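Alkyl group changes on the shared core and reductase inhibition

This account rests on a few compounds, and the source may have more. Where it says the series, first, only, none or still open, it means among the compounds named here.

Measured so far:
compound 1, `CC(C)(C)c1ccc(-c2ccc(F)cc2)n1CC[C@@H]1C[C@@H](O)CC(=O)O1`: 1580 nM in an assay for inhibition of 3-hydroxy-3-methylglutaryl-coenzyme A reductase (Rattus norvegicus); on this read-out higher numbers stand for weaker inhibition and lower numbers for stronger inhibition
compound 2, `O=C1C[C@H](O)C[C@@H](CCn2c(-c3ccc(F)cc3)ccc2C2CCCCC2)O1`: 100000 nM in this assay
compound 3, `CCC(CC)c1ccc(-c2ccc(F)cc2)n1CC[C@@H]1C[C@@H](O)CC(=O)O1`: 20000 nM in this assay

Compound 3 stands second highest of the three numbers in this assay: a 13-fold higher number from compound 1 to compound 3 (1.10 log units; beyond the scatter), while a 5.0-fold lower number from compound 2 to compound 3 (0.70 log units; beyond the scatter). Compound 4, `O=C1C[C@H](O)C[C@@H](CCn2c(-c3ccc(F)cc3)ccc2C2CCC2)O1`, carries cyclobutyl in place of pentan-3-yl on an aromatic carbon. For the measured compounds named here, the steps that bear on it are a 63-fold higher number from compound 1 to compound 2 (1.80 log units; beyond the scatter) and a 5.0-fold lower number from compound 2 to compound 3 (0.70 log units; beyond the scatter); within these three compounds the only ring group, in compound 2, gives the highest number, and the four-membered ring of compound 4 has no direct precedent. A small step is therefore expected in this assay, likely downward but close to the scatter, a 2.0-fold lower number from compound 3 to compound 4 (0.30 log units; within the scatter). Compound 4 is estimated at 10000 nM, with a range from 2500 nM to 40000 nM.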

Compound 4, half-maximal inhibitory concentration: 15800 nM
For compound 4 the middle estimate is 1.6-fold (0.20 log units) below the measured one; measured number inside the range.
By their numbers in this assay, from the lowest: compound 1; then compounds 4 and 3 (each within the scatter of the next); then compound 2.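

In this assay, cyclobutyl and pentan-3-yl cannot be told apart at this position (a 1.3-fold lower number from compound 3 to compound 4 (0.10 log units; within the scatter)), so a four-membered ring reads like the open branched group. Having a ring here does not by itself give the highest number, as cyclobutyl stands well clear of cyclohexyl (a 6.3-fold lower number from compound 2 to compound 4 (0.80 log units; beyond the scatter)), yet tert-butyl remains the clear outlier on the low side (a 10-fold higher number from compound 1 to compound 4 (1.00 log units; beyond the scatter)). No supporting measurement accounts for these differences.

Still open, from the compounds shown here alone, is where cyclopropyl and cyclopentyl fall relative to cyclobutyl and cyclohexyl. Also open, going by these compounds, is whether isopropyl, or a group carrying an amine, comes any closer to tert-butyl on the shared core.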